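This account rests on a few compounds, and the source may have more. Where it says the series, first, only, none or still open, it means among the compounds named here.

Measured compounds:
- compound 1, `O=C(CI)NCCCCC(=O)NCCCCCCNc1ncnc2c1ncn2[C@@H]1O[C@H](COP(=O)(O)OP(=O)(O)OP(=O)(O)O)[C@@H](O)[C@H]1O`: 0%
- compound 2, `Nc1ncnc2c1nc(NCCCCNC(=O)CI)n2[C@@H]1O[C@H](COP(=O)(O)OP(=O)(O)OP(=O)(O)O)[C@@H](O)[C@H]1O`: 0%
- compound 3, `CN(CCCN(C)C(=O)CCCCNc1ncnc2c1ncn2[C@@H]1O[C@H](COP(=O)(O)OP(=O)(O)OP(=O)(O)O)[C@@H](O)[C@H]1O)C(=O)CCCCNC(=O)CI`: 0%

In an assay on isolated protein for inhibition of hexokinase-1 (Rattus norvegicus), with a stated time of 6 h, tested at 10 mM (on this read-out lower numbers stand for less inhibition and higher numbers for more inhibition at the one concentration tested (going by the name of the read-out)), compound 1 gives 0%. Compound 2 gives 0% in this assay, and compound 3 gives 0%. Compound 1 therefore stands level with compound 2 and with compound 3 at the digits reported; the differences between any two of these three values lie within the usual scatter of such measurements, so nothing can be said about which of them inhibits more or less. All three share the same core carrying the triphosphate sugar, and each carries an iodoacetamide group at the end of a chain.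

Compound 4, `O=C(CI)NCCCC(=O)NCCCCCCNc1ncnc2c1ncn2[C@@H]1O[C@H](COP(=O)(O)OP(=O)(O)OP(=O)(O)O)[C@@H](O)[C@H]1O`, has not yet been measured. It differs from compound 1 in one place: ((iodomethyl)carbonyl)amino in place of (((iodomethyl)carbonyl)amino)methyl on a saturated chain carbon, three bonds along the chain from a carbonyl carbon. The rest of the molecule is unchanged.

Among the compounds with values here, no pair of measured compounds differs in only one place, so no measured step shows what a change of this kind does in this assay. The three measured values give no sign that any of these chains inhibits at this concentration. For compound 4 the expected step from its parent is no change at the digits printed from compound 1 to compound 4 (within the scatter), that is, none beyond the scatter. For compound 4 the estimated value is 0%, with a range from 0% to 10%.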

Compound 4, a percentage reported as inhibition, at one concentration (the size of the read-out at that concentration, not a potency): 0%
Compound 4: middle estimate and measured number agree at the digits printed, within the range that was stated.
By their numbers in this assay, from the lowest: compounds 1, 2, 3 and 4 (each within the scatter of the next).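

In this assay, the chain carrying the iodoacetamide group is one carbon shorter in compound 4, with ((iodomethyl)carbonyl)amino in place of (((iodomethyl)carbonyl)amino)methyl on a saturated chain carbon, three bonds along the chain from a carbonyl carbon, and the result is no change at the digits printed from compound 1 to compound 4 (within the scatter) for this change. Within the data shown here, this is the first pair that differs in only one place, so this position now has a measured step, and compound 4 at 0% shows that this shorter chain does not bring out any inhibition at the one concentration tested, although a step between two compounds that both read zero cannot show how chain length affects the size of an inhibition that is actually present. Nothing measured here offers an explanation for this result.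

Still open, from the compounds shown here alone, is whether any chain at this position gives a reading above zero, for instance a much shorter chain, a longer chain than that of compound 1, or a chain without the inner amide. Going by these compounds, it is also open whether a different reactive end, such as a bromoacetamide or an acrylamide in place of the iodoacetamide group, would change the picture in this assay on the shared core.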